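Extending the hydroxycarbamoyl chain of compound 1

A few compounds are considered here, and "the series" means these few. Any claim that something is new, unique, unknown or untested is made for them only; others in the source may bear on it.

Compound 1 `O=C(CCCC(=O)Nc1ccc(NC(=O)Nc2ccc(Cl)c(C(F)(F)F)c2)cc1)NO` was tested in a functional assay on A549 cells (Homo sapiens) for inhibition, read by sulforhodamine B assay, with a stated time of 48 h; a higher number here means a weaker inhibitor, a lower number a stronger inhibitor. Compound 1 reads > 10000 nM, which is a limit and not a number. Compound 3 `O=C(Nc1ccc(Nc2ncc(C(=O)NO)cn2)cc1)Nc1ccc(Cl)c(C(F)(F)F)c1` reads > 10000 nM, which is also a limit. Among the compounds with values here, compound 2 `O=C(/C=C/c1ccc(NC(=O)Nc2ccc(Cl)c(C(F)(F)F)c2)cc1)NO` gives 3400 nM, the only true number so far. Compound 1 therefore sits at the limit of > 10000 nM in this assay, at which 2 of the 3 values shown sit.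

Compound 4 `O=C(CCCCCCC(=O)Nc1ccc(NC(=O)Nc2ccc(Cl)c(C(F)(F)F)c2)cc1)NO` keeps the core of compound 1 and lengthens the chain: 3-(hydroxycarbamoyl)propyl in place of hydroxycarbamoyl on a saturated chain carbon, three bonds along the chain from a carbonyl carbon. This places 3-(hydroxycarbamoyl)propyl in place of hydroxycarbamoyl on a saturated chain carbon, three bonds along the chain from a carbonyl carbon.

Two measured steps alter this end of compound 1, and neither is a pure change of chain length. The first gave an at least 2.9-fold lower number from compound 1 to compound 2 (0.46 log units; beyond the scatter), which is beyond the scatter. The second gave a step that the two limits leave unreadable from compound 1 to compound 3. Within the data shown here, only the step to compound 2 at 3400 nM shows that a change at this end can bring a readable value. A modest move towards a lower number is therefore expected, though another limit remains quite possible. The expected step is an at least 2.0-fold lower number from compound 1 to compound 4 (0.30 log units; that floor lies within the scatter). Compound 4 is estimated at 5000 nM, with an expected range of 1500 nM to 15000 nM.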

Compound 4, half-maximal inhibitory concentration: 9500 nM
The estimate for compound 4 lay 1.9-fold (0.28 log units) below the measured number; low and high end bracket the measured number.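

Within the data shown here, compound 4 is the first compound with a saturated chain at this end to give a true number in this assay: compound 4 reads 9500 nM, so 3-(hydroxycarbamoyl)propyl in place of hydroxycarbamoyl, on a saturated chain carbon three bonds along the chain from a carbonyl carbon, brings the reading within the range of the assay. A readable value at this end therefore does not depend on the 2-(hydroxycarbamoyl)ethenyl group of compound 2. The size of the gain stays unproven, however, with an at least 1.0-fold lower number from compound 1 to compound 4 (0.02 log units; that floor lies within the scatter), and compound 1 remains a limit and not a number, so only a floor can be given for this step: the limit of > 10000 nM in this assay, at which 2 of the 4 values shown sit.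

With a single readable chain length, the data cannot show whether potency in this series follows chain length or whether compound 4 sits near an optimum, and a longer chain such as 6-(hydroxycarbamoyl)hexyl extended by further carbons would test that. As far as these compounds go, whether the hydroxycarbamoyl end is needed at all also stays open, and a carboxylic acid or a primary amide at the end of the same chain would address it.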